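The source may report more compounds than this note shows. Statements on the series, on what has been measured and on what is new or still open speak of the compounds shown alone.

Two compounds of the series have numbers in a functional assay on cells for antagonist activity at Free fatty acid receptor 1 (Homo sapiens), read by TR-FRET and inositol phosphate accumulation, with a stated time of 2 h (a lower number here means a stronger inhibitor, a higher number a weaker inhibitor), so far. Compound 1 `Cc1cc(COc2ccc(F)cc2F)nc(-c2ccccn2)n1` gives 398 nM. Compound 2 `CC1(C#N)CN(c2cc(COc3ccc(F)c(F)c3F)nc(-c3ccccn3)n2)C1` gives 158 nM, the lower of the two numbers, and its gap to compound 1 lies beyond the scatter. Within the data shown here, no single-point step between them is available, as the two differ in more than one place, so the pair only shows its two values. Compound 3 `COC1(COc2cc(COc3ccc(F)c(F)c3F)nc(-c3ccccn3)n2)COC1` is the next to be measured. It differs from compound 2 in one place: (3-methoxyoxetan-3-yl)methoxy in place of 3-cyano-3-methylazetidin-1-yl on an aromatic carbon. Among the measured compounds shown here, no measured step of this kind exists among the two compounds, so the numbers give no direction; a step toward a higher number, of modest size and close to the scatter, seems the likeliest outcome. The value estimated for compound 3 in this assay is 250 nM, with a range from 100 nM to 700 nM. That estimate corresponds to an expected step of a 1.6-fold higher number from compound 2 to compound 3 (0.20 log units; within the scatter).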

Compound 3, half-maximal inhibitory concentration: 501 nM
Compound 3: the middle estimate sits 2.0-fold (0.30 log units) below what was measured; the range from low to high includes it.
By their numbers in this assay, from the lowest: compound 2; then compounds 1 and 3 (each within the scatter of the next).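

In this assay, among these compounds, the one single-place step at this aromatic carbon is a 3.2-fold higher number from compound 2 to compound 3 (0.50 log units; beyond the scatter), with (3-methoxyoxetan-3-yl)methoxy in place of 3-cyano-3-methylazetidin-1-yl, so the number does depend on the group held at this position. Both groups carry a four-membered non-aromatic ring with 1 hetero atom and no hydrogen-bond donors, and these shared features do not hold the number at the level of compound 2. Nothing at hand explains the direction or size of this step.

The exchange alters the nitrile, the ring hetero atom and the attachment to the aromatic carbon together, so the step cannot be assigned to any one of them. On these data alone, how a plain azetidin-1-yl, a morpholine or a carboxylic acid at this carbon would compare with compound 2 remains open.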